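Does Dropping the Chloro Substituent Change Antiproliferative Activity?

The compounds below may be only part of what the source reports. "The series", "measured", "known", "first", "only" and "open" are said of these compounds alone.

Measured compounds:
compound 1, `N=C(NO)N/N=C/c1ccc(Cl)cc1`: > 100000 nM
compound 2, `COc1ccccc1/C=N/N=C(\N)NO`: > 100000 nM

Of the compounds shown here, two have been tested in a functional assay on HL-60 cells (Homo sapiens) for antiproliferative activity; on this read-out higher numbers stand for weaker inhibition and lower numbers for stronger inhibition. Compound 1 `N=C(NO)N/N=C/c1ccc(Cl)cc1` gives > 100000 nM, which is a limit of the assay rather than a number. Compound 2 `COc1ccccc1/C=N/N=C(\N)NO` likewise gives > 100000 nM, again a limit. Compound 1 therefore stands exactly where every value shown stands, namely at the limit of > 100000 nM in this assay, at which 2 of the 2 values shown sit.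

Compound 3 `N=C(NO)N/N=C/c1ccccc1` has not yet been measured in this assay. It differs from compound 1 by hydrogen in place of chloro on an aromatic carbon. For the measured compounds named here, no pair of measured compounds shares this kind of change, so the size of its effect cannot be read from measured steps. Given that compound 1 reports only > 100000 nM, compound 3 is expected to show no step beyond the scatter in this assay, an estimated step that the limit leaves unreadable from compound 1 to compound 3. Compound 3 is expected to give about 150000 nM, within 50000 nM to 500000 nM, most probably again as a limit.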

Compound 3, half-maximal inhibitory concentration: 62000 nM
Estimate against measurement, compound 3: 2.4-fold (0.38 log units) above; the range from low to high includes it.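

In this assay, for the compounds shown here, compound 3 gives 62000 nM, the first true number rather than a limit, so the core carrying hydrogen on this aromatic carbon can be read on the scale of the assay. Replacing chloro with hydrogen gives an at least 1.6-fold lower number from compound 1 to compound 3 (0.20 log units; that floor lies within the scatter), so the data alone do not establish a change larger than ordinary repeat variation. The real size of the step could be larger, but it stays unreadable because the comparison starts from a limit: the limit of > 100000 nM in this assay, at which 2 of the 3 values shown sit.

From the compounds shown here alone, what remains open is whether the chloro group itself matters or whether any change at this carbon would give a similar result. How an amine, a carboxylic acid or a longer chain at the same place would compare with hydrogen also cannot be told from these compounds.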